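Methyl for Fluoro on a Weakly Active Amide Series

The compounds below may be only part of what the source reports. "The series", "measured", "known", "first", "only" and "open" are said of these compounds alone.

Of the compounds shown here, three with a shared core have been tested in a functional assay on PC-3 cells (Homo sapiens) for cytotoxicity, read by MTT assay, with a stated time of 72 h; a higher number here means a weaker inhibitor, a lower number a stronger inhibitor. Compound 1 `COc1ccc(-c2ccnc(C(=O)Nc3ccc(Oc4ccnc5[nH]ccc45)cc3)n2)cc1` carries a methoxyphenyl group on its central ring and gives 17300 nM, so it inhibits the cells only at a high concentration. Compound 2 `O=C(Nc1ccc(Oc2ccnc3[nH]ccc23)cc1)c1nccc(-c2ccc(F)cc2)n1` is reported as "not active" (no number reported). The central ring of compound 2 is arranged differently in compound 3 `O=C(Nc1ccc(Oc2ccnc3[nH]ccc23)cc1)c1cc(-c2ccc(F)cc2)ncn1`, and compound 3 is likewise reported as "not active" (no number reported). Going by the values given here, compound 3 therefore stands without a number at all, as one of two entries in this set that show no measurable inhibition, while compound 1 is the only compound with a measured value, and that value is weak.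

Among the compounds with values here, compound 4 `Cc1ccc(-c2cc(C(=O)Nc3ccc(Oc4ccnc5[nH]ccc45)cc3)ncn2)cc1` is the one compound still to be measured. It differs from compound 3 in a single place: methyl in place of fluoro on an aromatic carbon. Within the data shown here, no step between measured compounds is available to calibrate this change, and the nearest comparison, compound 3, has no number. Since the closest analogue shows no activity, the step in this assay is expected to be small, with no clear direction, and probably not beyond the usual scatter. Compound 4 is expected to give about 40000 nM, within a range of 12000 nM to 100000 nM, with a high chance that only an inactive result is reported.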

Compound 4, half-maximal inhibitory concentration: 9880 nM
Compound 4: the middle estimate sits 4.0-fold (0.61 log units) above what was measured; the measured number lies below the stated range.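

Going by these compounds alone, compound 4 gives 9880 nM and compound 3 is reported as "not active", without a number, so no step between compound 3 and compound 4 can be read. No measurement shown here accounts for this result. The compounds shown leave open how far 4-fluorophenyl to 4-methylphenyl alone shifts activity on these cells.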